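A few compounds are considered here, and "the series" means these few. Any claim that something is new, unique, unknown or untested is made for them only; others in the source may bear on it.

Measured compounds:
compound 1, `COC(=O)c1c(Nc2ccccc2)sc(C(=O)c2ccc(OC)cc2)c1C`: 48.1%
compound 2, `COC(=O)c1c(Nc2ccc(C)cc2)sc(C(=O)c2ccc(OC)cc2)c1C`: "not active" (no number reported)
compound 3, `COc1ccc(C(=O)c2sc(Nc3ccccc3)c(C(=O)O)c2C)cc1`: 59.5%

Within the data shown here, in a functional assay, with a stated time of 150 min, tested at 30 ug/mL (a higher number here means a stronger effect of the compound at the concentration tested, a lower number a weaker effect), compound 3 gives the higher of the two numbers; the one measured step, a number 11.4 percentage points higher from compound 1 to compound 3 (beyond the scatter), is modest but beyond the scatter. Compound 2 gives no number at all.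

Compound 4, `COc1ccc(C(=O)c2sc(Nc3ccc(C)cc3)c(C(=O)O)c2C)cc1`, is to be measured in this assay. It differs from compound 3 in one place: methyl in place of hydrogen on an aromatic carbon. Among the measured compounds shown here, no measured step carries this change on the acid, but the pair compound 1 and compound 2 shows the same difference on the methyl ester: compound 1 gives 48.1% in this assay, whereas compound 2 is reported only as "not active" (no number reported). That pair points to a loss of effect on methyl in place of hydrogen on an aromatic carbon. For compound 4 a drop beyond the scatter is therefore expected, with a fair chance that no number at all is reported. Compound 4 is estimated at 20%, between 0% and 45%. The expected step is a number 39.5 percentage points lower from compound 3 to compound 4 (beyond the scatter).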

Compound 4, a percentage reported as activity, at one concentration (the size of the read-out at that concentration, not a potency): "not active" (no number reported)
Nothing numeric was reported for compound 4; no gap can be computed for the estimate.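

Compound 4 gives no number in this assay, and neither does compound 2, so no new step can be read from compound 3 or compound 1. Nothing available bears on a cause for this result. The compounds shown leave open the size of the loss from phenyl to 4-methylphenyl, on either the acid or the methyl ester.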